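Ring contraction of the aminocycloalkyl amide on the shared core

This account rests on a few compounds, and the source may have more. Where it says the series, first, only, none or still open, it means among the compounds named here.

Compound 3 `Cn1cc(-c2cnc3c(-c4csc(C(=O)N[C@@H]5CCCC[C@@H]5N)c4)cnn3c2)cn1` stands at the floor of the values shown: in an assay for inhibition of MAP/microtubule affinity-regulating kinase 3 (Homo sapiens), read by HTRF, with a stated time of 2 h (on this read-out higher numbers stand for weaker inhibition and lower numbers for stronger inhibition), compound 3 gives <= 0.5 nM, which is a limit of the assay rather than a number. Compound 4 `Cn1cc(-c2cnc3c(-c4csc(C(=O)N[C@@H]5CCC[C@@H]5N)c4)cnn3c2)cn1` carries a group of 6 heavy atoms (5 carbon, 1 nitrogen; one five-membered non-aromatic ring of carbon only) in place of a group of 7 heavy atoms (6 carbon, 1 nitrogen; one six-membered non-aromatic ring of carbon only), on an amide-type nitrogen. Going by the values given here, the bearing step is the reverse of the one from compound 1 `Cn1cc(-c2cnc3c(-c4csc(C(=O)N[C@@H]5CCC[C@H]5N)c4)cnn3c2)cn1`, which gives 3 nM, to compound 3, namely an at least 6.0-fold lower number from compound 1 to compound 3 (0.77 log units; beyond the scatter); compound 4 keeps the five-membered ring of compound 1 but differs from it at its stereocentres, so that step is only a partial guide. Compound 2 `Cn1cc(-c2cnc3c(-c4csc(C(=O)N[C@@H]5CCCC[C@H]5O)c4)cnn3c2)cn1` gives 24 nM and does not bear on a ring change alone. A modest rise is therefore expected, an at least 4.0-fold higher number from compound 3 to compound 4 (0.60 log units; beyond the scatter), and compound 4 is estimated at 2 nM within 0.4 nM to 10 nM.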

Compound 4, half-maximal inhibitory concentration in the MAP/microtubule affinity-regulating kinase 3 assay: 2 nM
Beside the measured number, compound 4's estimate shows no gap at the digits printed, within the range that was stated.
By their numbers in the MAP/microtubule affinity-regulating kinase 3 assay, from the lowest: compounds 4 and 1 (each within the scatter of the next); then compound 2. At a limit, below all of these: compound 3.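

In the MAP/microtubule affinity-regulating kinase 3 assay compound 3 gives <= 0.5 nM as a limit of the assay and not a number. In the MAP/microtubule affinity-regulating kinase 3 assay the ring contraction can be sized from one side only, and an at least 4.0-fold higher number from compound 3 to compound 4 (0.60 log units; beyond the scatter) rests on that limit. In the MAP/microtubule affinity-regulating kinase 3 assay the five-membered amine stays well clear of the six-membered alcohol, a 12-fold lower number from compound 2 to compound 4 (1.08 log units; beyond the scatter), though ring and group change together in that step. In the MAP/microtubule affinity-regulating kinase 3 assay the one stereocentre drawn differently on the five-membered ring shifts nothing beyond the scatter, a 1.5-fold lower number from compound 1 to compound 4 (0.18 log units; within the scatter): the fact that compounds 1 and 4 differ only in the configuration as drawn In a physicochemical assay for solubility, at pH 7 (on this read-out higher numbers stand for higher solubility and lower numbers for lower solubility), compound 3 gives 68000 nM and compound 4 gives 69000 nM with no separation beyond the scatter.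

From the compounds shown here alone, how far compound 3 truly lies past its limit stays open. So does whether an open-chain 2-aminoethyl group would hold this potency in place of either ring.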